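Swapping a Sulfonamide for an Amide on a Shorter Chain

This account rests on a few compounds, and the source may have more. Where it says the series, first, only, none or still open, it means among the compounds named here.

Measured in a functional assay on SK-MEL-28 cells (Homo sapiens) for cytotoxicity, read by MTT assay; a lower number here means a stronger inhibitor, a higher number a weaker inhibitor:
Compound 1, `O=C(NCCNc1nccc(-c2c(-c3cccc(F)c3)nc3sccn23)n1)c1c(F)cccc1F`, gives 11400 nM.
Compound 2, `O=S(=O)(NCCNc1nccc(-c2c(-c3cccc(F)c3)nc3sccn23)n1)c1ccc(Cl)cc1`, gives 18600 nM.
Compound 3, `O=S(=O)(NCCCNc1nccc(-c2c(-c3cccc(F)c3)nc3sccn23)n1)c1ccc(Cl)cc1`, gives 8450 nM.

Compound 3 shows the lowest of the three numbers, yet a 1.3-fold lower number from compound 1 to compound 3 (0.13 log units; within the scatter) is within the scatter; only a 2.2-fold lower number from compound 2 to compound 3 (0.34 log units; beyond the scatter) stands beyond it. Compound 4, `O=C(NCCNc1nccc(-c2c(-c3cccc(F)c3)nc3sccn23)n1)c1ccc(Cl)cc1`, arises from compound 3 by the change (((4-chlorophenyl)carbonyl)amino in place of (((4-chlorophenyl)sulfonyl)amino)methyl on a saturated chain carbon, two bonds along the chain from a nitrogen on an aromatic ring). For the measured compounds named here, two measured steps bear on this. The chain shortening reverses a 2.2-fold lower number from compound 2 to compound 3 (0.34 log units; beyond the scatter), and the exchange of sulfonyl for carbonyl resembles the reverse of a 1.6-fold higher number from compound 1 to compound 2 (0.21 log units; within the scatter), which stayed within the scatter. Together these suggest a somewhat higher number, and the expected step is a 1.4-fold higher number from compound 3 to compound 4 (0.15 log units; within the scatter), probably not beyond the scatter. Compound 4 is estimated at 12000 nM, within a range from 5000 nM to 30000 nM.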

Compound 4, half-maximal inhibitory concentration: 8160 nM
Compound 4: middle estimate off by 1.5-fold (0.17 log units), on the high side; measured number inside the range.
By their numbers in this assay, from the lowest: compounds 4, 3, 1 and 2 (each within the scatter of the next, the first and the last beyond it).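

With the 4-chlorophenyl and the chain held fixed, (4-chlorophenyl)carbonyl in place of (4-chlorophenyl)sulfonyl on an amine nitrogen gives a 2.3-fold lower number from compound 2 to compound 4 (0.36 log units; beyond the scatter) in this assay, so this exchange alone moves the number beyond the scatter. Yet 4-chlorophenyl in place of 2,6-difluorophenyl on a carbonyl carbon gives only a 1.4-fold lower number from compound 1 to compound 4 (0.15 log units; within the scatter), and the step with the sulfonamide on the longer chain is a 1.0-fold lower number from compound 3 to compound 4 (0.02 log units; within the scatter). Nothing measured here explains these steps. Still open, from the compounds shown here alone, is how the carbonyl compound would read on a longer chain, and how an amine or a carboxylic acid in place of the 4-chlorophenyl would read.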